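This account rests on a few compounds, and the source may have more. Where it says the series, first, only, none or still open, it means among the compounds named here.

The measured compounds are:

Compound 1, `O=c1[nH]c(/C=C/c2ccccc2Br)nc2ccccc12`: in a functional assay on SK-N-MC cells (Homo sapiens) for cytotoxicity, read by MTT assay, with a stated time of 72 h (a higher number here means a weaker inhibitor, a lower number a stronger inhibitor), compound 1 reaches only a limit, > 6250 nM.
Compound 2, `O=c1[nH]c(/C=C/c2cccc(Cl)c2)nc2ccccc12`: in this assay compound 2 likewise reaches only a limit, > 6250 nM.
Compound 3, `Clc1nc(/C=C/c2ccccc2)nc2ccccc12`: in this assay compound 3 gives 4960 nM.

For the measured compounds named here, compound 3 therefore stands alone as the one compound with an actual number; compounds 1 and 2 stand at the limit of > 6250 nM in this assay, at which 2 of the 3 values shown sit. Going by the values given here, no pair of measured compounds differs in a single place, so nothing measured here tells how a substituent on the phenyl ring shifts the read-out for this core, and nothing ties the chloro-bearing core of compound 3 to the other two by a single step.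

Compound 4, `COc1ccccc1/C=C/c1nc(Cl)c2ccccc2n1`, differs from compound 3 by methoxy in place of hydrogen on an aromatic carbon. Among the compounds with values here, with no measured step to lean on, the account can only expect a modest move: a methoxy group of this kind usually leaves a read-out of this sort close to where it was, so the expected step of a 1.2-fold lower number from compound 3 to compound 4 (0.09 log units; within the scatter) is small and not beyond the scatter. Compound 4 is accordingly estimated at about 4000 nM, within a range from 1500 nM to 12000 nM.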

Compound 4, half-maximal inhibitory concentration: 580 nM
The estimate for compound 4 lay 6.9-fold (0.84 log units) above the measured number; the measured number lies below the stated range.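

In this assay, methoxy on an aromatic carbon of the six-membered ring of carbon only, ortho to a large group, gives an 8.6-fold lower number from compound 3 to compound 4 (0.93 log units; beyond the scatter). For the compounds shown here, this is the first single-place step in the set, and it shows that this position on the ring is not silent for the core shared by compound 3 and compound 4: a change of only 2 heavy atoms there moves the read-out beyond the scatter, towards a stronger inhibitor. Compound 1 and compound 2 could not show this, as each stays a limit rather than a number and neither lies one step from another compound:  the limit of > 6250 nM in this assay, at which 2 of the 4 values shown sit.

Going by these compounds alone, the single step gives size and direction but not the reason for the move, and it leaves open whether a hydroxyl group, an amine, fluorine or a longer chain such as ethoxy would act like methoxy at the same carbon, or whether methoxy would do the same on another carbon of that ring. It also leaves open whether methoxy would have a like effect on the core of compound 1, which carries a carbonyl and an amide hydrogen in place of the chlorine of compound 4.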